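A Chloro Substituent Tested on an Inactive Core

The source may report more compounds than this note shows. Statements on the series, on what has been measured and on what is new or still open speak of the compounds shown alone.

Compound 1 `Nc1nc(-c2ccccc2)nn1-c1ncnc2ccccc12` is the starting point, and in an assay on MCF7 cells for inhibition of Serine-protein kinase ATM (Homo sapiens), read by immunofluorescence, with a stated time of 1 h (a higher number here means a weaker inhibitor, a lower number a stronger inhibitor), compound 1 gives only a limit, > 40000 nM, not a measured number. Compound 2 `COc1ccc(-c2nc(N)n(-c3ncnc4ccccc34)n2)cc1` carries a methoxy in place of hydrogen on an aromatic carbon, and in this assay compound 2 likewise gives only the limit > 40000 nM. The step that the two limits leave unreadable from compound 1 to compound 2 therefore cannot be read, because the limit of > 40000 nM in this assay, at which 2 of the 2 values shown sit, shows both values resting at the same limit. Compound 3 `Nc1nc(-c2ccccc2)nn1-c1ncnc2cc(Cl)ccc12` differs from compound 1 by chloro in place of hydrogen on an aromatic carbon. Among the measured compounds shown here, the single measured step gives no readable size, so there is no basis for expecting a shift beyond the scatter in either direction, and a further limit seems the most probable outcome. The estimated step from compound 1 to compound 3 is a number no higher from compound 1 to compound 3 (the limit leaves the size open). Compound 3 is expected to give about 40000 nM, within a range of 10000 nM to 100000 nM, in this assay.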

Compound 3, half-maximal inhibitory concentration: > 40000 nM
Compound 3 was reported as a limit; the forecaster's own chance of this, stated with the estimate: 80%; the middle value lies on the limit itself.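

The step from compound 1 to compound 3 cannot be read, because both compounds give only a limit: the limit of > 40000 nM in this assay, at which 3 of the 3 values shown sit.

The compounds shown leave open whether a chloro or methoxy in place of hydrogen on an aromatic carbon changes inhibition at all in this assay.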